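Amine substituent variation on the propoxy chain

The compounds below may be only part of what the source reports. "The series", "measured", "known", "first", "only" and "open" are said of these compounds alone.

Measured so far:
compound 1 `COc1cc2c(Oc3c(F)cc(NC(=O)NN4C(=O)CSC4c4c(F)cccc4F)cc3F)ccnc2cc1OCCCN1CCCC1` — 560 nM
compound 2 `COc1cc2c(Oc3c(F)cc(NC(=O)NN4C(=O)CSC4c4c(F)cccc4F)cc3F)ccnc2cc1OCCCN1C[C@H]2CCCC[C@H]2C1` — 1930 nM

Both compounds were run in a functional assay on A549 cells (Homo sapiens) for antiproliferative activity, read by MTT assay, with a stated time of 72 h; on this read-out higher numbers stand for weaker inhibition and lower numbers for stronger inhibition. Compound 2 stands highest of the two numbers; its nearest neighbour is compound 1, with the step of a 3.4-fold higher number from compound 1 to compound 2 (0.54 log units; beyond the scatter).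

Compound 3 `CCN1CCN(CCCCOc2cc3nccc(Oc4c(F)cc(NC(=O)NN5C(=O)CSC5c5c(F)cccc5F)cc4F)c3cc2OC)CC1` is not yet measured. It differs from compound 2 by a group of 9 heavy atoms (7 carbon, 2 nitrogen; one six-membered non-aromatic ring with 2 hetero atoms) in place of a group of 9 heavy atoms (8 carbon, 1 nitrogen; one five-membered non-aromatic ring with 1 hetero atom, one six-membered non-aromatic ring of carbon only), on a saturated chain carbon, three bonds along the chain from an oxygen on an aromatic ring. Within the data shown here, the only step that touches this position is the one from compound 1 to compound 2, where the bicyclic amine enters in place of the pyrrolidine and the number rises by a 3.4-fold higher number from compound 1 to compound 2 (0.54 log units; beyond the scatter). Among the measured compounds shown here, compound 3 removes that bicyclic amine again and puts the 4-ethylpiperazin-1-yl group in its place, so the expectation is that the number in this assay falls back toward the value of compound 1, though the piperazine itself has no precedent and the size of the return is uncertain. The step from compound 2 to compound 3 is therefore expected to be a 2.6-fold lower number from compound 2 to compound 3 (0.41 log units; beyond the scatter). Compound 3 is estimated at 750 nM, within a range of 300 nM to 1900 nM.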

Compound 3, half-maximal inhibitory concentration: 1390 nM
The estimate for compound 3 lay 1.9-fold (0.27 log units) below the measured number; low and high end bracket the measured number.
By their numbers in this assay, from the lowest: compound 1; then compounds 3 and 2 (each within the scatter of the next).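

In this assay the bicyclic amine and the (4-ethylpiperazin-1-yl)methyl group do not separate at this position, with a 1.4-fold lower number from compound 2 to compound 3 (0.14 log units; within the scatter) as the step between them, so the two groups read alike here despite their different rings. The higher number is therefore not peculiar to the bicyclic amine: compound 3 also stays apart from compound 1, with a 2.5-fold higher number from compound 1 to compound 3 (0.39 log units; beyond the scatter) alongside the earlier 3.4-fold higher number from compound 1 to compound 2 (0.54 log units; beyond the scatter) as the two steps away from pyrrolidin-1-yl, and among these three compounds pyrrolidin-1-yl carries the lowest number. No supporting measurement is available to explain why either larger group gives the higher number.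

The (4-ethylpiperazin-1-yl)methyl change alters the ring and adds a methylene in one step, so the contribution of each remains unresolved, and the 4-ethylpiperazin-1-yl group on the same chain as the pyrrolidine in compound 1 would separate them. Going by these compounds, whether the lower number belongs to pyrrolidin-1-yl alone or extends to other small amines, such as dimethylamino or morpholin-4-yl at this chain carbon, also remains open.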